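The compounds below may be only part of what the source reports. "The series", "measured", "known", "first", "only" and "open" are said of these compounds alone.

Measured so far:
Compound 1 `CC(=O)N1CCC(c2cc3c(-c4ccc(=O)n(C(C)C)c4)ccnc3[nH]2)CC1` gives < 3 uL/min in an ADME assay on microsomes from liver (Homo sapiens) for metabolic stability; on this read-out higher numbers stand for fast clearance and lower numbers for slow clearance.
Compound 2 `CC(C)n1cc(-c2ccnc3[nH]c(C4CCN(CC(=O)N(C)C)CC4)cc23)cnc1=O` gives 24 uL/min.
Compound 3 `CC(C)Cn1cc(-c2ccnc3[nH]c(C4CCN(CC(=O)N(C)C)CC4)cc23)ccc1=O` gives 21 uL/min.

For compound 1 the value is a limit of the assay, not a number; it sits at the limit of < 3 uL/min in this assay, at which 1 of the 3 values shown sits. Compound 4 `CC(C)n1cc(-c2ccnc3[nH]c(C4CCN(CC(=O)N5CCCCC5)CC4)cc23)ccc1=O` has not yet been measured in this assay. It differs from compound 1 in one place: ((piperidin-1-yl)carbonyl)methyl in place of acetyl on an amine nitrogen in a ring. Going by the values given here, no measured pair shows exactly this change, so the expectation rests on the other two compounds, whose amide groups also sit on that ring nitrogen and which clear far faster than compound 1. The step of an at least 10-fold higher number from compound 1 to compound 4 (1.00 log units; beyond the scatter) is expected to be a rise well beyond the usual scatter. For compound 4 the expected value is 30 uL/min, with a likely range from 10 uL/min to 90 uL/min.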

Compound 4, intrinsic clearance in a liver preparation (reported as CLH), per the amount of preparation that the assay uses: > 300 uL/min
Compound 4: a limit, no number; the forecaster's own chance of this, stated with the estimate: 5%; middle value at least 10-fold (1.00 log units) from the limit.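

This one position can carry the read-out from one end of its range to the other: in this assay, ((piperidin-1-yl)carbonyl)methyl in place of acetyl on an amine nitrogen in a ring gives an at least 100-fold higher number from compound 1 to compound 4 (2.00 log units; beyond the scatter). Compound 1 sits at a limit of the assay, not at a number: the limit of < 3 uL/min in this assay, at which 1 of the 4 values shown sits. Compound 4 sits at the opposite limit, also not a number: the limit of > 300 uL/min in this assay, at which 1 of the 4 values shown sits.

As far as these compounds go, the true size of the step therefore stays open. So does which part of the entering group matters, and where a plain methyl or a morpholine amide on that nitrogen would fall.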